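This account rests on a few compounds, and the source may have more. Where it says the series, first, only, none or still open, it means among the compounds named here.

Measured in a functional assay (QGY7701 cells, Homo sapiens) for inhibition, read by MTT assay, with a stated time of 48 h; on this read-out higher numbers stand for weaker inhibition and lower numbers for stronger inhibition:
compound 1 `Cc1ccc(CNC(=O)/C=C/c2coc3cc(O)ccc3c2=O)cc1`: 24900 nM
compound 2 `COc1ccc2c(=O)c(/C=C/C(=O)NCc3ccc(F)cc3)coc2c1`: 7960 nM
compound 3 `COc1ccc(CNC(=O)/C=C/c2coc3cc(O)ccc3c2=O)cc1`: 10000 nM

Among these three, compound 2 and compound 3 lie within the usual scatter of each other in this assay, so no order between them can be read from the numbers. Among the compounds with values here, compound 1 sits beyond the scatter above both; the only one-point step, a 2.5-fold lower number from compound 1 to compound 3 (0.40 log units; beyond the scatter), carries a methoxy in place of methyl on an aromatic carbon and gives a modest change.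

Compound 4 `COc1ccc2c(=O)c(/C=C/C(=O)Nc3ccc(F)cc3)coc2c1` differs from compound 2 in one place: 4-fluorophenyl in place of 4-fluorobenzyl on an amide-type nitrogen. Within the data shown here, no measured step in this set concerns the group on the amide-type nitrogen; the step from compound 1 to compound 3 changes the aromatic ring of the shared core instead and does not bear on this change. With nothing to go on, no step beyond the scatter is expected in this assay in either direction, and the range must be kept wide. Compound 4 is therefore estimated at 8000 nM, between 2500 nM and 25000 nM, which corresponds to an expected step of a 1.0-fold higher number from compound 2 to compound 4 (0.00 log units; within the scatter).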

Compound 4, half-maximal inhibitory concentration: > 100000 nM
Compound 4 was reported as a limit; the forecaster's own chance of this, stated with the estimate: 5%; middle value at least 12-fold (1.09 log units) away from the limit.
By their numbers in this assay, from the lowest: compounds 2 and 3 (each within the scatter of the next); then compound 1. At a limit, above all of these: compound 4.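

In this assay, the group on the amide-type nitrogen proves to be a sensitive point in the series: 4-fluorophenyl in place of 4-fluorobenzyl gives an at least 12-fold higher number from compound 2 to compound 4 (1.09 log units; beyond the scatter). Within the data shown here, compounds 1, 2 and 3 all keep a benzyl group on this nitrogen, and the one earlier step, a 2.5-fold lower number from compound 1 to compound 3 (0.40 log units; beyond the scatter), is modest, so they gave no sign of such a large response to a change here. Compound 4 is reported as a limit and not as a number: the limit of > 100000 nM in this assay, at which 1 of the 4 values shown sits.

Going by these compounds, this reading rests on a single pair, so it remains open whether the same change would act alike on the core of compound 1. Also open, on these data alone, is how a longer chain, such as 2-phenylethyl, would behave on the amide-type nitrogen.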